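This account rests on a few compounds, and the source may have more. Where it says the series, first, only, none or still open, it means among the compounds named here.

Working notes on the series. Within the data shown here, in an assay on Sf9 cells for inhibition of protein deacetylase HDAC6 (Homo sapiens), read by fluorescence (a lower number here means a stronger inhibitor, a higher number a weaker inhibitor), compound 1 `Cc1cc(-c2nnc(Sc3ccc(C(=O)NO)c(F)c3)n2C)nn1C` gives 2240 nM, the higher of the two numbers known so far; compound 2 `Cn1c(Sc2c(F)cc(C(=O)NO)cc2F)nnc1-c1cccnn1` gives 13 nM in this assay, a lower number well beyond the scatter. Compound 3 `Cc1cc(-c2nnc(Sc3ccc(C(=O)NO)cc3)n2C)nn1C` differs from compound 1 only by hydrogen in place of fluoro on an aromatic carbon. Among the measured compounds shown here, no pair differing in one place has yet been measured, so the size of this step is not known from the series; the expectation for compound 3 is a step of about a 1.3-fold higher number from compound 1 to compound 3 (0.10 log units; within the scatter), that is no change beyond the scatter, with a slight weakening more likely than a gain. Compound 3 is accordingly estimated at 2800 nM, within 1100 nM to 7000 nM.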

Compound 3, half-maximal inhibitory concentration: 5 nM
For compound 3 the middle estimate is 560-fold (2.75 log units) above the measured one, and the stated range ends above it.
By their numbers in this assay, from the lowest: compound 3; then compound 2; then compound 1.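

In this assay, hydrogen in place of fluoro on the aromatic carbon ortho to the hydroxycarbamoyl group gives a 450-fold lower number from compound 1 to compound 3 (2.65 log units; beyond the scatter) on an otherwise unchanged core. This position is therefore highly sensitive to this change, with a single fluorine atom separating the two compounds. Nothing available on these compounds accounts for the size of this step.

From the compounds shown here alone, whether chloro, methyl or methoxy at this position would behave like fluoro or like hydrogen remains open. So does whether the same change carries a step of this size on the core of compound 2.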